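Cytotoxicity notes: side-chain changes on a shared core

The source may report more compounds than this note shows. Statements on the series, on what has been measured and on what is new or still open speak of the compounds shown alone.

Compound 1 `O=c1[nH]c(=O)n(C2C[C@@H](O)[C@@H](CO)O2)nc1/C=C(\F)Br` in a functional assay on Vero cells (Chlorocebus sabaeus) for cytotoxicity; on this read-out higher numbers stand for weaker inhibition and lower numbers for stronger inhibition: > 500 ug/mL, a limit of the assay.
Compound 2 `O=Cc1nn(C2C[C@@H](O)[C@@H](CO)O2)c(=O)[nH]c1=O`: 180 ug/mL.
Compound 3 `O=C(O)/C=C/c1nn(C2C[C@@H](O)[C@@H](CO)O2)c(=O)[nH]c1=O`: > 500 ug/mL, a limit of the assay.

Compound 3 stands at the upper end of what this series shows; its value is a limit, and it shares that position with the limit of > 500 ug/mL in this assay, at which 2 of the 3 values shown sit. Going by the values given here, the only numbered value in the set belongs to compound 2. The readable step is an at least 2.7-fold higher number from compound 2 to compound 3 (0.44 log units; beyond the scatter), so replacing formyl by 2-carboxyethenyl pushes the number out of the measurable range. The step that the two limits leave unreadable from compound 1 to compound 3, since both ends are limits. The remaining step, an at least 2.7-fold lower number from compound 1 to compound 2 (0.44 log units; beyond the scatter), shows that formyl is the one side chain in this set that brings a measurable number.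

Compound 4 `O=c1[nH]c(=O)n(C2C[C@@H](O)[C@@H](CO)O2)nc1CC(F)(F)F` differs from compound 3 in one place: 2,2,2-trifluoroethyl in place of 2-carboxyethenyl on an aromatic carbon. Among the compounds with values here, no measured step covers 2,2,2-trifluoroethyl directly. Compound 1, which also carries a halogen-bearing group on this ring carbon, sits at the limit > 500 ug/mL. Compound 4 is therefore expected to remain at or near that limit, with an estimate of 500 ug/mL and a range from 200 ug/mL to 1000 ug/mL. The expected step is a number no higher from compound 3 to compound 4 (the limit leaves the size open), that is, none beyond the scatter, with a limit rather than a number the likely outcome.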

Compound 4, concentration for 50% inhibition: > 500 ug/mL
Compound 4 ended at the assay's limit; the forecaster's own chance of this, stated with the estimate: 70%; the middle value lies on the limit itself.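

In this assay, a third side chain on this aromatic carbon ends at the same ceiling: compound 4 gives > 500 ug/mL, a limit of the assay and not a number. Going by these compounds alone, the one readable step, an at least 2.7-fold higher number from compound 2 to compound 4 (0.44 log units; beyond the scatter), shows for 2,2,2-trifluoroethyl the same direction that 2-carboxyethenyl showed against formyl, although 2,2,2-trifluoroethyl counts 0 hydrogen-bond donors and 0 hydrogen-bond acceptors and 2-carboxyethenyl counts 1 of each, so these counts do not separate the two side chains in this set. The steps from compound 1 and from compound 3 to compound 4 cannot be read, and the series now gathers at one end: the limit of > 500 ug/mL in this assay, at which 3 of the 4 values shown sit.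

Going by these compounds, how far the three side chains at the limit differ from one another stays open, as the shared limit hides any such difference. On these data alone, it is also open whether a measurable number belongs to formyl alone, or would also appear with an amine, a nitrile or a longer chain such as propyl on this aromatic carbon.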